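Swapping the amine on the core: compound 3 to compound 4

The source may hold more compounds than are shown below. What is called first, only, known or untested is meant among the compounds shown, and "the series" means these compounds.

The shared core is a two-ring system carrying a (methoxycarbonyl)methyl group. Compound 3 `COC(=O)CC1c2ccccc2N=C(N2CCCCC2)N1C1CCCCC1` stands second highest of the three numbers measured in a functional assay on cells (Oocyte) for inhibition of Voltage-dependent T-type calcium channel subunit alpha-1H (Homo sapiens), tested at 100 uM (on this read-out higher numbers stand for more inhibition at the one concentration tested (going by the name of the read-out) and lower numbers for less inhibition), where compound 3 gives 27%; compound 1 `COC(=O)CC1c2ccccc2N=C(N2CCOCC2)N1c1ccccc1` gives 14%, and compound 2 `COC(=O)CC1c2ccccc2N=C(c2ccccc2)N1c1ccccc1` gives 51.5%. Compound 4 `COC(=O)CC1c2ccccc2N=C(N2CCN(C)CC2)N1C1CCCCC1` differs from compound 3 in one place: 4-methylpiperazin-1-yl in place of piperidin-1-yl on a carbon with a double bond to nitrogen. Among the compounds with values here, the only measured step at that carbon, a number 37.5 percentage points higher from compound 1 to compound 2 (beyond the scatter), exchanged an amine ring for phenyl, not one amine ring for another, so it does not directly predict this change; the values of compound 1 and compound 3 show that two different amine rings give numbers in the same lower region. The step of a number 5 percentage points lower from compound 3 to compound 4 (within the scatter) is therefore expected to be small. Compound 4 is estimated at 22%, within 8% to 38%.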

Compound 4, a percentage reported as inhibition, at one concentration (the size of the read-out at that concentration, not a potency): 3%
Compound 4: middle estimate off by 19 percentage points, on the high side; measured number outside the range, below it.
By their numbers in this assay, from the lowest: compound 4; then compound 1; then compound 3; then compound 2.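

Swapping one six-membered amine ring for another at this carbon is not a neutral change, as the step (a number 24 percentage points lower from compound 3 to compound 4 (beyond the scatter)) shows: the position responds to differences among amine rings, not only to an amine ring giving way to phenyl. No measurement shown here gives a reason for this step. As far as these compounds go, it remains open whether the added ring nitrogen or its methyl group matters, which piperazin-1-yl without the methyl group could help separate. From the compounds shown here alone, whether phenyl also gives a higher number alongside cyclohexyl remains open too.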